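The source may hold more compounds than are shown below. What is called first, only, known or untested is meant among the compounds shown, and "the series" means these compounds.

Measured compounds in an assay for inhibition of protein disulfide-isomerase (Homo sapiens), with a stated time of 1 h; on this read-out higher numbers stand for weaker inhibition and lower numbers for stronger inhibition: compound 1 `Cc1ccnc(NC(c2ccc(C(F)(F)F)cc2)c2ccc3cccnc3c2O)c1` with 26500 nM and compound 2 `CCc1ccc(C(Nc2cc(C)ccn2)c2ccc3cccnc3c2O)cc1` with 5390 nM.

Among the measured compounds shown here, of the two measured compounds, compound 2 stands lowest, its only neighbour being compound 1, which sits at a higher number, and the gap between them is beyond the scatter. Compound 3 `Cc1ccnc(NC(c2ccc(OCc3ccccc3)cc2)c2ccc3cccnc3c2O)c1` differs from compound 2 in one place: benzyloxy in place of ethyl on an aromatic carbon. For the measured compounds named here, the only measured step, a 4.9-fold lower number from compound 1 to compound 2 (0.69 log units; beyond the scatter), concerns the same aromatic carbon, where ethyl replaced trifluoromethyl, and it is modest in size. Going by the values given here, no measured pair shows what a benzyloxy group does at this position, so that step is the sole guide, and it says the position tolerates change without a large swing. A small movement in the this assay number is therefore expected for compound 3, with the direction uncertain, as a 1.3-fold lower number from compound 2 to compound 3 (0.13 log units; within the scatter). Compound 3 is estimated at 4000 nM, within a range of 1200 nM to 13000 nM.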

Compound 3, half-maximal inhibitory concentration: 620 nM
Estimate against measurement, compound 3: 6.5-fold (0.81 log units) above; the whole stated range lies above it.
By their numbers in this assay, from the lowest: compound 3; then compound 2; then compound 1.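

In this assay, replacing ethyl with benzyloxy on this aromatic carbon gives an 8.7-fold lower number from compound 2 to compound 3 (0.94 log units; beyond the scatter), and replacing trifluoromethyl with benzyloxy gives a 43-fold lower number from compound 1 to compound 3 (1.63 log units; beyond the scatter). Among the compounds shown here, the position therefore accepts a much larger group carrying its own six-membered aromatic ring, and the number falls further across the three compounds, with no compound here going against that order. Nothing available accounts for this drop in the number.

Benzyloxy brings its oxygen and its ring together, so the compounds shown cannot say which of the two goes with the lower number; a methoxy group or a plain phenyl group at this carbon would separate them. On these data alone, how a longer chain, an amine or a carboxylic acid would behave here also stays open.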